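The source may hold more compounds than are shown below. What is called first, only, known or untested is meant among the compounds shown, and "the series" means these compounds.

Working notes on the series. The shared core carries a benzamide and an N-benzyl arm; the three measured compounds differ only in the substituent on that benzyl ring. Compound 1 `Cc1cccc(CN2Cc3c(NC(=O)c4ccccc4)n[nH]c3C2(C)C)c1` gives in an assay on Sf21 cells for inhibition of high affinity nerve growth factor receptor (Homo sapiens), read by HTRF, with a stated time of 30 min, in the presence of a further agent that is not named here (on this read-out lower numbers stand for stronger inhibition and higher numbers for weaker inhibition), a value of 1100 nM. Compound 2 `COc1cccc(CN2Cc3c(NC(=O)c4ccccc4)n[nH]c3C2(C)C)c1` gives in this assay a value of 1120 nM. Compound 3 `CC1(C)c2[nH]nc(NC(=O)c3ccccc3)c2CN1Cc1cccc(I)c1` gives in this assay a value of 1360 nM. On these numbers compound 3 is not set apart: the step of a 1.2-fold higher number from compound 1 to compound 3 (0.09 log units; within the scatter) and the step of a 1.2-fold higher number from compound 2 to compound 3 (0.08 log units; within the scatter) are both within the scatter, as is the step of a 1.0-fold higher number from compound 1 to compound 2 (0.01 log units; within the scatter) between the other two.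

Compound 4 `CC1(C)c2[nH]nc(NC(=O)c3ccccc3)c2CN1Cc1cccc(Cl)c1` is the next point. The change is chloro in place of iodo on an aromatic carbon. Going by the values given here, the steps that bear on it are the three substituent swaps at the same place, methyl to methoxy, methyl to iodo and methoxy to iodo, none of which moved the number beyond the scatter. A fourth swap at that place is therefore expected to give no step beyond the scatter, and the estimated step is a 1.1-fold lower number from compound 3 to compound 4 (0.05 log units; within the scatter). Compound 4 is estimated at 1200 nM in this assay, with a range from 600 nM to 2400 nM.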

Compound 4, half-maximal inhibitory concentration: 670 nM
Estimate against measurement, compound 4: 1.8-fold (0.25 log units) above; low and high end bracket the measured number.
By their numbers in this assay, from the lowest: compounds 4, 1, 2 and 3 (each within the scatter of the next, the first and the last beyond it).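

At this place on the benzyl ring, a substituent swap has now moved the number beyond the scatter in this assay: chloro in place of iodo gives a 2.0-fold lower number from compound 3 to compound 4 (0.31 log units; beyond the scatter), a modest step. The other two steps to the chloro compound, a 1.7-fold lower number from compound 2 to compound 4 (0.22 log units; within the scatter) and a 1.6-fold lower number from compound 1 to compound 4 (0.22 log units; within the scatter), remain within the scatter, so chloro is separated only from iodo and not from methoxy or methyl. No measurement available here explains this separation.

From the compounds shown here alone, the place has been probed only with methyl, methoxy, iodo and chloro, so the effect of an amine, a carboxylic acid or a longer chain there remains open. The benzamide is also the same throughout, leaving open how a change at that part of the series would affect the number.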